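The compounds below may be only part of what the source reports. "The series", "measured", "known", "first", "only" and "open" are said of these compounds alone.

Measured so far in a functional assay on DU-145 cells (Homo sapiens) for antiproliferative activity, read by MTT assay, with a stated time of 24 h; on this read-out lower numbers stand for stronger inhibition and higher numbers for weaker inhibition:
Compound 1 `c1ccc(-c2noc(-c3ccncc3)n2)cc1`: 657000 nM
Compound 2 `COc1cc(-c2noc(-c3ccncc3)n2)ccc1OCc1ccccc1`: > 1000000 nM
Compound 3 `COc1ccc(-c2noc(-c3cccnc3)n2)cc1OC1CCCC1`: > 1000000 nM

Compound 1 is the only one of the three with a measured number, and in this assay compound 1 gives 657000 nM, a weak effect. For compound 2 the assay reports only a limit, > 1000000 nM. For compound 3 the result is likewise only a limit, > 1000000 nM. Compound 3 therefore stands at the limit of > 1000000 nM in this assay, at which 2 of the 3 values shown sit, and its true number is not known; on what is shown nothing sets it apart from compound 2.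

Compound 4 `COc1ccc(-c2noc(C3CCNCC3)n2)cc1OC1CCCC1` has not yet been measured. It differs from compound 3 in one place: piperidin-4-yl in place of pyridin-3-yl on an aromatic carbon. Among the compounds with values here, no step between measured compounds is available to calibrate such a change, and all three measured values are weak or at the limit. Compound 4 is therefore expected to remain weak, with the step from the limit of compound 3 estimated as an at least 1.2-fold lower number from compound 3 to compound 4 (0.09 log units; that floor lies within the scatter), which is not expected to exceed the scatter by much. Compound 4 is estimated at 800000 nM, in the range 250000 nM to 3000000 nM, with a fair chance that again only a limit is reported.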

Compound 4, half-maximal inhibitory concentration: 57 nM
Compound 4: middle estimate off by 14000-fold (4.15 log units), on the high side; the whole stated range lies above it.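

In this assay, piperidin-4-yl in place of pyridin-3-yl on the aromatic carbon of the five-membered ring gives an at least 17000-fold lower number from compound 3 to compound 4 (4.24 log units; beyond the scatter), the only step among these compounds and one far beyond the scatter. This position can therefore decide between almost no effect and strong inhibition, although both groups have 6 heavy atoms (5 carbon, 1 nitrogen) and differ in having a non-aromatic or an aromatic ring and 1 or 0 hydrogen-bond donors. The full size of the step cannot be read, as the value for compound 3 is only a limit: the limit of > 1000000 nM in this assay, at which 2 of the 4 values shown sit.

The compounds shown do not separate the change in the ring from the added hydrogen-bond donor. As far as these compounds go, a cyclohexyl group or an open-chain amine at this position would bear on that question, and whether the effect holds on the core of compound 1 remains open.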